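A few compounds are considered here, and "the series" means these few. Any claim that something is new, unique, unknown or untested is made for them only; others in the source may bear on it.

Working notes on the series. Three analogues share one core and differ in the group on an aromatic carbon: compound 1 (`CN(C)c1nc(N)nc2c1ncn2/C=C1/CC1(CO)CO`), compound 2 (`Nc1nc(NCc2ccccc2)c2ncn(/C=C3/CC3(CO)CO)c2n1`) and compound 3 (`Nc1nc(NC2CCCCC2)c2ncn(/C=C3/CC3(CO)CO)c2n1`). In an ADME assay on MOLT-3 cells (Homo sapiens) for cytotoxicity, with a stated time of 7 days (a higher number here means that more compound is tolerated, a lower number that less compound is tolerated), compound 1 has the entry "not determined" (no result reported) and gives no number. Compound 2 reads > 20000 nM in this assay and this is a limit of the assay, not a number. Compound 3 stands at "not determined" (no result reported) in this assay and so offers no single number as a starting point. Within the data shown here, the only reading in the set is therefore the limit of > 20000 nM in this assay, at which 1 of the 3 values shown sits, and it belongs to compound 2.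

The next structure is compound 4 (`CC(C)Sc1nc(N)nc2c1ncn2/C=C1/CC1(CO)CO`). The change isopropylsulfanyl in place of cyclohexylamino on an aromatic carbon puts isopropylsulfanyl in place of cyclohexylamino on an aromatic carbon, next to the ring nitrogen, and the rest of the core stays the same. Among the measured compounds shown here, no measured pair in the set gives the size of such a swap, so the expected step in this assay is none beyond the usual scatter, in either direction. That expectation rests on compound 2 alone, whose limit of > 20000 nM is the only anchor, and a further limit reading for compound 4 would be no surprise. For compound 4 the estimated half-maximal cytotoxic concentration is 20000 nM with an expected range of 6000 nM to 60000 nM in this series.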

Compound 4, half-maximal cytotoxic concentration: > 20000 nM
Compound 4 was reported as a limit; the forecaster's own chance of this, stated with the estimate: 60%; the middle value sits exactly at the limit.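

No step can be read between compound 2 and compound 4, since both entries in this assay are limits and not numbers: the limit of > 20000 nM in this assay, at which 2 of the 4 values shown sit.

The compounds shown leave open whether isopropylsulfanyl and benzylamino differ at all in this assay, and where the half-maximal cytotoxic concentration of either compound lies.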